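Swapping one small side group on the shared core

The compounds below may be only part of what the source reports. "The series", "measured", "known", "first", "only" and "open" are said of these compounds alone.

Compound 1, `CSc1nnc(Cc2ccc(Cl)cc2Oc2ccccc2Cl)[nH]1`, gives 132% in a functional assay on the whole organism (strain NMRI) with Mus musculus as the target, with a stated time of 60 min, at a dose of 10 mg/kg by the intraperitoneal route; on this read-out higher numbers stand for a stronger effect at the one dose given and lower numbers for a weaker effect.
Compound 2, `CSc1nnc(Cc2ccc(Cl)cc2Oc2ccccc2F)[nH]1`, gives 121% in this assay.
Compound 3, `Nc1nnc(Cc2ccc(Cl)cc2Oc2ccccc2F)o1`, gives 129% in this assay.

Compound 1 has the highest of the three numbers, though the number of compound 3 lies within the usual scatter of it, so the two cannot be ranked. Only compound 2 is set apart, by the step of a number 11 percentage points lower from compound 1 to compound 2 (beyond the scatter), a modest fall that came with fluoro in place of chloro on an aromatic carbon.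

Compound 4, `CCOc1nnc(Cc2ccc(Cl)cc2Oc2ccccc2Cl)[nH]1`, differs from compound 1 in one place: ethoxy in place of methylsulfanyl on an aromatic carbon. Neither measured step touches this spot. The step of a number 11 percentage points lower from compound 1 to compound 2 (beyond the scatter) swaps a halogen on a far ring, and the step of a number 8 percentage points higher from compound 2 to compound 3 (within the scatter) exchanges the whole five-membered ring for another; both moved the read-out little, and the ring exchange stayed within the scatter. With no closer guide, the change in compound 4 is expected to leave the read-out roughly where compound 1 sits, a step of a number 7 percentage points lower from compound 1 to compound 4 (within the scatter), with nothing beyond the scatter foreseen. Compound 4 is therefore estimated to give 125% in this assay, with a likely range from 100% to 150%.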

Compound 4, a percentage reported as activity, at one dose (the size of the read-out at that dose, not a potency): 122%
Compound 4: the middle estimate sits 3 percentage points above what was measured; the measured number falls inside the stated range.
By their numbers in this assay, from the lowest: compounds 2, 4, 3 and 1 (each within the scatter of the next, the first and the last beyond it).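

In this assay, for the compounds shown here, the step of a number 10 percentage points lower from compound 1 to compound 4 (within the scatter) gives the first reading at this position, on an aromatic carbon between two ring nitrogen atoms, where the earlier steps changed a halogen or the whole five-membered ring. It shows that ethoxy can stand in place of methylsulfanyl without a change that can be told apart from the scatter, at least at this one dose, which gives the size of the effect and not a potency. Nothing measured here explains why the read-out holds at this position.

What the compounds shown leave open is how far this tolerance reaches: whether a longer chain such as butoxy, or a carboxylic acid, would also keep the read-out in this range at the same position. They also leave open whether ethoxy would behave the same way when combined with fluoro in place of chloro on an aromatic carbon, the change that separated compound 2 from compound 1.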